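Shortening a long chain on two related cores

This account rests on a few compounds, and the source may have more. Where it says the series, first, only, none or still open, it means among the compounds named here.

Compound 1, `CCCCCCCCCCCCCCCCc1c(C)c(N(C)C)nc(C)c1O`, carries a long chain on its core, and in a functional assay on cells (Lymphocyte, Homo sapiens) for inhibition, read by flow cytometry, using a membrane potential dye, with a stated time of 16 h, tested at 250 nM (a higher number here means a stronger effect of the compound at the concentration tested, a lower number a weaker effect), compound 1 gives 83%. Compound 2, `CCCCCCCCCCCCCCCCCCCc1c(C)c(N(C)C)nc(C)c1O`, differs only in a longer chain, and in this assay compound 2 gives 42%. The change from compound 2 to compound 1 is hydrogen in place of propyl on a saturated chain carbon, ten or more bonds along the chain from an aromatic carbon, and it brings a number 41 percentage points higher from compound 2 to compound 1 (beyond the scatter).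

Compound 3, `CCCCCCCCCCCCCCCCCCCc1nc(N(C)C)c(C)c(C)c1O`, has the same atoms as compound 2 joined differently; the difference between the two cores is not broken down here. In this assay compound 3 gives 44%, which lies within the scatter of the value of compound 2, so the two cores with the longer chain cannot be told apart.

Compound 4, `CCCCCCCCCCCCCCCCc1nc(N(C)C)c(C)c(C)c1O`, is to compound 3 what compound 1 is to compound 2: the change is hydrogen in place of propyl on a saturated chain carbon, ten or more bonds along the chain from an aromatic carbon, the same change made in the same place. Because compound 2 to compound 1 showed a number 41 percentage points higher from compound 2 to compound 1 (beyond the scatter), the step from compound 3 to compound 4 is expected to be about a number 34 percentage points higher from compound 3 to compound 4 (beyond the scatter), though it rests on a single measured pair. Compound 4 is estimated to give 78%, with a range from 55% to 95%.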

Compound 4, a percentage reported as activity, at one concentration (the size of the read-out at that concentration, not a potency): 84%
For compound 4 the middle estimate is 6 percentage points below the measured one, and the stated range covers the measured number.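

On the second core, the same shortening of the chain, hydrogen in place of propyl, gives a number 40 percentage points higher from compound 3 to compound 4 (beyond the scatter) in this assay. Set beside the first core, the change carries over with a step of nearly the same size: the same change on two cores in this assay, a number 41 percentage points higher (beyond the scatter) from compound 2 to compound 1 and a number 40 percentage points higher (beyond the scatter) from compound 3 to compound 4, 1 percentage points apart, within the scatter of two such steps This agreement rests on only two matched pairs, one chain change and one assay at a single concentration, so it does not show that the step would carry over to other cores, nor does it explain why the shorter chain gives the higher number.

The compounds shown leave open whether a still shorter chain, or a chain carrying an amine or a carboxylic acid, would continue this trend on either core. On these data alone, each number here also comes from one concentration, and how these compounds compare at other concentrations remains open.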